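Trimming the allyl back to methyl on the core nitrogen

The source may hold more compounds than are shown below. What is called first, only, known or untested is meant among the compounds shown, and "the series" means these compounds.

Compound 1 `CCCN(c1nc(-c2ccc(Cl)cc2)n(C)n1)C(C1CC1)C1CC1`: 33 nM
Compound 2 `CCCN(c1nc(-c2c(C)cc(C)cc2C)n(CC)n1)C(C1CC1)C1CC1`: 310 nM
Compound 3 `C=CCn1nc(N(CCC)C(C2CC2)C2CC2)nc1-c1c(C)cc(C)cc1C`: 2200 nM

In an assay on CHO cells for binding affinity to corticotropin-releasing factor receptor 1 (Homo sapiens) (a higher number here means a weaker inhibitor, a lower number a stronger inhibitor), compound 3 gives the highest number of the three measured, so it is the weakest of this set; compound 2 comes nearest and compound 1 lies furthest below it. Compound 4 `CCCN(c1nc(-c2c(C)cc(C)cc2C)n(C)n1)C(C1CC1)C1CC1` differs from compound 3 by a single cut: hydrogen in place of vinyl on a saturated chain carbon bound to an aromatic nitrogen, so the allyl group becomes a methyl. One measured step speaks to this position: a 7.1-fold higher number from compound 2 to compound 3 (0.85 log units; beyond the scatter), where enlarging methyl to vinyl on that chain carbon raised the number beyond the scatter. Removing the vinyl again is therefore expected to move the number down, a step estimated as an 8.8-fold lower number from compound 3 to compound 4 (0.94 log units; beyond the scatter). Compound 4 is accordingly expected to reach about 250 nM, within a range of 80 nM to 800 nM.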

Compound 4, inhibition constant: 120 nM
Beside the measured number, compound 4's estimate is 2.1-fold (0.32 log units) above it; the range from low to high includes it.
By their numbers in this assay, from the lowest: compound 1; then compound 4; then compound 2; then compound 3.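

In this assay the cut from allyl to methyl gives an 18-fold lower number from compound 3 to compound 4 (1.26 log units; beyond the scatter) and so goes further than undoing the earlier rise from ethyl to allyl. The change from ethyl to methyl alone gives a 2.6-fold lower number from compound 2 to compound 4 (0.41 log units; beyond the scatter) so even one carbon less at this position counts. Among these three compounds the number rises in the order methyl in compound 4, ethyl in compound 2, allyl in compound 3.

On these data alone, whether a longer chain such as propyl, or a chain ending in an amine, would extend this order stays open. Nothing available here bears on the reason for the order.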